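Cytotoxicity notes on the shared core: nitro analogue

A few compounds are considered here, and "the series" means these few. Any claim that something is new, unique, unknown or untested is made for them only; others in the source may bear on it.

Compound 2 `CCOC(=O)c1c(-c2cccc(OCC(C)C)c2)[nH]c2cc(OC)ccc2c1=O` stands at the limit of an ADME assay on HepG2 cells (Homo sapiens) for cytotoxicity, read by luminescence, with a stated time of 72 h; a higher number here means that more compound is needed for the effect, a lower number that less compound is needed: compound 2 gives > 21500 nM, a limit rather than a number. Compound 1 `CCOC(=O)c1c(-c2cccc(OCC)c2)[nH]c2cc(OC)ccc2c1=O` gives > 21500 nM in this assay, also a limit. Compound 3 `CCOC(=O)c1c(-c2cccc(C(F)(F)F)c2)[nH]c2cc(OC)ccc2c1=O` gives > 21500 nM in this assay, again a limit. Compound 4 `CCOC(=O)c1c(-c2cccc([N+](=O)[O-])c2)[nH]c2cc(OC)ccc2c1=O` is unmeasured and differs from compound 2 by nitro in place of isobutoxy on an aromatic carbon. The steps touching the same aromatic carbon are a step that the two limits leave unreadable from compound 2 to compound 3 and a step that the two limits leave unreadable from compound 1 to compound 3, and a step that the two limits leave unreadable from compound 1 to compound 2 is equally unreadable because of the limit of > 21500 nM in this assay, at which 3 of the 3 values shown sit. No readable step guides the direction or size of the change to compound 4. Compound 4 is therefore expected to stay at the limit, with an estimated 30000 nM (range 10000 nM to 100000 nM). The expected step is a step that the limit leaves unreadable from compound 2 to compound 4, none beyond the scatter.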

Compound 4, half-maximal effective concentration: > 21500 nM
Compound 4 gave a limit, no number; the forecaster's own chance of this, stated with the estimate: 85%; the middle value is on the limit's open side.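

Compound 4 adds no readable step to compound 1, compound 2 or compound 3 in this assay, because all four sit at one limit: the limit of > 21500 nM in this assay, at which 4 of the 4 values shown sit.

The compounds shown leave open whether any group on this aromatic carbon of the shared core gives a measurable number rather than a limit.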